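Dimethylamino to Nitro on the Shared Core

The compounds below may be only part of what the source reports. "The series", "measured", "known", "first", "only" and "open" are said of these compounds alone.

Compound 2 `CCCS(=O)(=O)Nc1ccc(F)c(C(=O)c2n[nH]c3ncc(-c4ccc(N(C)C)cc4)cc23)c1F` gives 2.5% in an assay for binding affinity to dual specificity mitogen-activated protein kinase kinase 4 (Homo sapiens), read by KINOMEscan, tested at 100 nM (a higher number here means a weaker effect of the compound at the concentration tested, a lower number a stronger effect), the lowest of the two numbers measured. Within the data shown here, compound 1 `CCCS(=O)(=O)Nc1ccc(F)c(C(=O)c2n[nH]c3ncc(-c4ccccc4N)cc23)c1F` gives 23% in this assay, and the only measured step, a number 20.5 percentage points lower from compound 1 to compound 2 (beyond the scatter), alters the same aryl group. Compound 3 `CCCS(=O)(=O)Nc1ccc(F)c(C(=O)c2n[nH]c3ncc(-c4ccc([N+](=O)[O-])cc4)cc23)c1F` differs from compound 2 by nitro in place of dimethylamino on an aromatic carbon. Among the measured compounds shown here, the change touches the group of compound 2 that the step of a number 20.5 percentage points lower from compound 1 to compound 2 (beyond the scatter) brought in, yet no measured pair shows this exact exchange, so the direction is uncertain. For compound 3 the number in this assay is expected to rise, a step of a number 12.5 percentage points higher from compound 2 to compound 3 (beyond the scatter), to an estimated 15% within 2% to 45%.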

Compound 3, a percentage reported as activity, at one concentration (the size of the read-out at that concentration, not a potency): 4.2%
The estimate for compound 3 lay 10.8 percentage points above the measured number, and the stated range covers the measured number.
By their numbers in this assay, from the lowest: compounds 2 and 3 (each within the scatter of the next); then compound 1.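

In this assay the exchange of dimethylamino for nitro on this aromatic carbon, para to a large group, gives a number 1.7 percentage points higher from compound 2 to compound 3 (within the scatter) and so leaves the two groups indistinguishable here. The 4-nitrophenyl group also stands apart from 2-aminophenyl, with a number 18.8 percentage points lower from compound 1 to compound 3 (beyond the scatter) and this shows that the gap first seen with 4-(dimethylamino)phenyl is not tied to that one group. From the compounds shown here alone, whether the gap follows from the place of the substituent or from the group itself stays open, as does how a primary amine or a carboxylic acid on this carbon would read. No evidence at hand explains these numbers.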